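From Fluoro to Trifluoromethyl: Expecting Compound 4

This account rests on a few compounds, and the source may have more. Where it says the series, first, only, none or still open, it means among the compounds named here.

In an assay on microsomes from liver for inhibition of 3-hydroxy-3-methylglutaryl-coenzyme A reductase (Rattus norvegicus) (a higher number here means a weaker inhibitor, a lower number a stronger inhibitor), three compounds have been measured so far. Compound 1 `CC[C@H](C)C(=O)O[C@H]1C[C@H](O)C=C2C=C[C@H](C)[C@H](CCC(O)C[C@H](O)CC(=O)O)[C@]21C` gives 5 nM. Compound 2 `O=C(O)C[C@H](O)C[C@H](O)CCn1c(C(F)(F)F)nc(-c2ccccc2)c1-c1ccc(F)cc1` gives 31 nM. Compound 3 `O=C(O)C[C@H](O)C[C@H](O)CCn1c(C(F)(F)F)nc(-c2ccc(F)cc2)c1-c1ccc(F)cc1` gives 38 nM.

Compound 3 holds the highest of the three numbers. Its nearest neighbour is compound 2: the step of a 1.2-fold higher number from compound 2 to compound 3 (0.09 log units; within the scatter) lies within the scatter, so the two cannot be told apart on these numbers. Compound 1 stands furthest from compound 3, and the gap between their two values lies beyond the scatter.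

Compound 4 `O=C(O)C[C@H](O)C[C@H](O)CCn1c(C(F)(F)F)nc(-c2ccc(C(F)(F)F)cc2)c1-c1ccc(F)cc1` differs from compound 3 in one place: trifluoromethyl in place of fluoro on an aromatic carbon. Among the compounds with values here, the only measured step at this position, a 1.2-fold higher number from compound 2 to compound 3 (0.09 log units; within the scatter), exchanged hydrogen for fluoro and moved the number hardly at all. Within the data shown here, no measured step exchanges fluoro for trifluoromethyl, so the size of this step is not anchored by any pair in hand. With the nearest comparison having stayed within the scatter, compound 4 is expected to show at most a small step in this assay, a 1.3-fold higher number from compound 3 to compound 4 (0.12 log units; within the scatter), which may well fall within the scatter. Compound 4 is therefore estimated at 50 nM, with a range from 15 nM to 160 nM.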

Compound 4, half-maximal inhibitory concentration: 200 nM
Compound 4: middle estimate off by 4.0-fold (0.60 log units), on the low side; measured number outside the range, above it.
By their numbers in this assay, from the lowest: compound 1; then compounds 2 and 3 (each within the scatter of the next); then compound 4.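

In this assay, this carbon had given no readable difference between hydrogen and fluoro, but it does respond to the group placed on it: going from 4-fluorophenyl to 4-(trifluoromethyl)phenyl gives a 5.3-fold higher number from compound 3 to compound 4 (0.72 log units; beyond the scatter), a step beyond the scatter. The rise does not depend on which earlier compound serves as the reference, since trifluoromethyl in place of hydrogen on the same carbon gives a 6.5-fold higher number from compound 2 to compound 4 (0.81 log units; beyond the scatter), and compound 2 and compound 3 themselves remain within the scatter of each other. The position is therefore not indifferent to substitution, as the first pair alone might have suggested, though nothing in hand says why the number rises with trifluoromethyl.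

From the compounds shown here alone, with only hydrogen, fluoro and trifluoromethyl seen on this carbon, it remains open whether a chloro, methyl or methoxy group would stay level with compound 2 and compound 3 or rise towards compound 4. Going by these compounds, it is also open whether trifluoromethyl in place of fluoro on the other 4-fluorophenyl group of the shared core would raise the number in the same way.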